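Amino for hydroxy: a second instance in the series

The source may hold more compounds than are shown below. What is called first, only, known or untested is meant among the compounds shown, and "the series" means these compounds.

Compound 1 `Oc1ccc(/C=C/c2ccccc2O)cc1` gives 21 ug/mL in a functional assay on MCF7 cells (Homo sapiens) for inhibition, read by MTT assay, with a stated time of 2 days; on this read-out higher numbers stand for weaker inhibition and lower numbers for stronger inhibition. For the measured compounds named here, compound 3 `Nc1ccc(/C=C/c2ccccc2O)cc1` differs from it by amino in place of hydroxy on an aromatic carbon and gives 23 ug/mL in this assay; the step of a 1.1-fold higher number from compound 1 to compound 3 (0.04 log units; within the scatter) is the only measured example of this change. Compound 2 `COc1ccccc1/C=C/c1ccccc1O` gives 17.9 ug/mL in this assay; the difference between its core and that of compound 1 is not broken down here. Compound 4 `COc1ccccc1/C=C/c1ccccc1N`, not yet measured, differs from compound 2 by amino in place of hydroxy on an aromatic carbon, the same kind of change as from compound 1 to compound 3, though here the place is ortho to a large group rather than para to a group of 9 heavy atoms. Resting on compound 1 and compound 3 and their step of a 1.1-fold higher number from compound 1 to compound 3 (0.04 log units; within the scatter), the expected step is a 1.1-fold higher number from compound 2 to compound 4 (0.05 log units; within the scatter). Compound 4 is thus estimated at 20 ug/mL in this assay.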

Compound 4, half-maximal inhibitory concentration: > 100 ug/mL
Compound 4: a limit, no number; the forecaster's own chance of this, stated with the estimate: 5%; at least 5.0-fold (0.69 log units) between middle value and limit.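

In this assay, amino in place of hydroxy on an aromatic carbon gives an at least 5.5-fold higher number from compound 2 to compound 4 (0.74 log units; beyond the scatter), and this step is read from a limit of the assay, not from a number. In this pair of cores, the change does not carry over at the same size: the same change on two cores in this assay, a 1.1-fold higher number (0.04 log units; within the scatter) from compound 1 to compound 3 and an at least 5.5-fold higher number (0.74 log units; beyond the scatter) from compound 2 to compound 4, at least 5.1-fold (0.70 log units) apart, beyond the scatter of two such steps. This shows that the step cannot be transferred from the core of compound 1 to that of compound 2, but two pairs do not show its true size on the latter core or which part of the difference between the cores matters.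

Still open, going by these compounds, is whether only amino behaves this way at the place ortho to a large group. Fluoro or a carboxylic acid there would test this.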